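The compounds below may be only part of what the source reports. "The series", "measured", "known", "first", "only" and "open" are said of these compounds alone.

Compound 3 `CCCC(=O)N1CCC(NS(=O)(=O)c2ccc(NC(=O)c3ccc(CC)cc3)c3ccccc23)CC1` is the second highest of the three numbers recorded in an in vitro functional assay on CHO/Galpha16 cells for antagonist activity at C-C chemokine receptor type 8 (Homo sapiens), read by FLIPR (a lower number here means a stronger inhibitor, a higher number a weaker inhibitor), where compound 3 gives 10.8 nM. Its neighbours are compound 1 `CCCC(=O)N1CCC(NS(=O)(=O)c2ccc(NC(=O)c3ccccc3)c3ccccc23)CC1`, which gives 12.5 nM, and compound 2 `CCCC(=O)N1CCC(NS(=O)(=O)c2ccc(NC(=O)C3CCCCC3)c3ccccc23)CC1`, which gives 6.1 nM. The step of a 1.2-fold lower number from compound 1 to compound 3 (0.06 log units; within the scatter) and the step of a 1.8-fold higher number from compound 2 to compound 3 (0.25 log units; within the scatter) both stay within the scatter, while a 2.0-fold lower number from compound 1 to compound 2 (0.31 log units; beyond the scatter) is modest. Compound 4 `CCCC(=O)N1CCC(NS(=O)(=O)c2ccc(NC(=O)c3cc(C)oc3C(F)(F)F)c3ccccc23)CC1` differs from compound 3 in one place: 5-methyl-2-(trifluoromethyl)furan-3-yl in place of 4-ethylphenyl on a carbonyl carbon. Among the compounds with values here, no measured step covers a change of this kind; the earlier steps altered the group on the carbonyl carbon by modest amounts at most. For compound 4 a step of a 1.1-fold higher number from compound 3 to compound 4 (0.05 log units; within the scatter) is therefore expected, within the scatter, giving an estimated 12 nM with a range from 4 nM to 35 nM in this assay.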

Compound 4, half-maximal inhibitory concentration: 46.9 nM
For compound 4 the middle estimate is 3.9-fold (0.59 log units) below the measured one; measured number outside the range, above it.
By their numbers in this assay, from the lowest: compounds 2, 3 and 1 (each within the scatter of the next, the first and the last beyond it); then compound 4.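

In this assay the group on the carbonyl carbon proves able to weaken inhibition clearly: 5-methyl-2-(trifluoromethyl)furan-3-yl gives a 4.3-fold higher number from compound 3 to compound 4 (0.64 log units; beyond the scatter), alongside a 3.8-fold higher number from compound 1 to compound 4 (0.57 log units; beyond the scatter) and a 7.7-fold higher number from compound 2 to compound 4 (0.89 log units; beyond the scatter). Within the data shown here, compound 4 is thus the weakest of the four, and this group is the first here to move the number this far. Nothing available explains the loss. The compounds shown leave open whether the furan ring, the methyl or the trifluoromethyl accounts for it, and how a group carrying an amine or a carboxylic acid would fare on this carbonyl carbon.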